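The source may hold more compounds than are shown below. What is called first, only, known or untested is meant among the compounds shown, and "the series" means these compounds.

Among the measured compounds shown here, in an ADME assay on a cell-free system (plasma, Homo sapiens) (on this read-out higher numbers stand for a larger free fraction and lower numbers for a smaller free fraction), compound 1 `CCNC(=O)Nc1nc2cc(-c3cccnc3)c(=O)n(CC3CCCCC3)c2s1` with cyclohexylmethyl on an aromatic nitrogen gives 0.02 as the lower of the two numbers so far. Compound 2 `CCNC(=O)Nc1nc2cc(-c3cccnc3)c(=O)n(C(C)C(=O)O)c2s1` with 1-carboxyethyl in that place gives 0.22 and stands highest. Compound 3 `CCNC(=O)Nc1nc2cc(-c3cccnc3)c(=O)n(C(C)C(N)=O)c2s1` carries 1-carbamoylethyl instead, with amino in place of hydroxy on a carbonyl carbon. For the measured compounds named here, only one measured step bears on this: the large 11-fold higher number from compound 1 to compound 2 (1.04 log units; beyond the scatter) replaced the whole group on the aromatic nitrogen. Going by the values given here, the new change keeps the chain and alters only the end of it, and no measured compound carries the carbamoyl group. Only a small move toward a lower number is therefore expected, probably not beyond the scatter. The expected size is a 1.8-fold lower number from compound 2 to compound 3 (0.26 log units; within the scatter) and this remains a rough figure. Compound 3 is estimated at 0.12 in this assay (expected range 0.05 to 0.25).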

Compound 3, unbound fraction: 0.25
Compound 3: middle estimate off by 2.1-fold (0.32 log units), on the low side, within the range that was stated.
By their numbers in this assay, from the lowest: compound 1; then compounds 2 and 3 (each within the scatter of the next).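

In this assay, the end of the chain on the aromatic nitrogen can change from carboxy to carbamoyl with only a 1.1-fold higher number from compound 2 to compound 3 (0.06 log units; within the scatter), so at this position the two end groups cannot be told apart. Replacing cyclohexylmethyl with 1-carbamoylethyl gives a 13-fold higher number from compound 1 to compound 3 (1.10 log units; beyond the scatter), which shows that a large step at this position does not require the carboxy group. No measurement on hand accounts for the two end groups reading alike.

The compounds shown do not separate the contribution of the end group from that of the chain carrying it, and a plain ethyl group on the aromatic nitrogen would bear on this. Going by these compounds, whether an amine at the chain end, or a longer chain ending in carbamoyl, would read the same also remains open.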